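Swapping a propyl chain for a chlorinated aromatic ring

The compounds below may be only part of what the source reports. "The series", "measured", "known", "first", "only" and "open" are said of these compounds alone.

Compound 3 `CCCCn1c(CN2CCN(C(=O)C3CC3)CC2)nc2ccccc21` gives 18.2% in an assay on isolated protein for inhibition of aldehyde dehydrogenase 1A1 (Homo sapiens), read by spectrophotometry, tested at 10 uM (on this read-out lower numbers stand for less inhibition and higher numbers for more inhibition at the one concentration tested (going by the name of the read-out)), the lowest of the three numbers recorded there. Its neighbours are compound 1 `O=C(C1CC1)N1CCN(Cc2nc3ccccc3n2Cc2ccccc2F)CC1` with 40.7% and compound 2 `CC(C)CCn1c(CN2CCN(C(=O)C3CC3)CC2)nc2ccccc21` with 70%. Compound 4 `O=C(C1CC1)N1CCN(Cc2nc3ccccc3n2Cc2cccc(Cl)c2)CC1` has not yet been tested; it differs from compound 3 in one place: 3-chlorophenyl in place of propyl on a saturated chain carbon bound to an aromatic nitrogen.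

The step that bears most directly on this change runs the other way: replacing 2-fluorophenyl with propyl cost a number 22.5 percentage points lower from compound 1 to compound 3 (beyond the scatter). Putting an aromatic ring back in that position, now bearing a chlorine instead of a fluorine, should therefore be expected to recover roughly that amount. The other steps, a number 29.3 percentage points higher from compound 1 to compound 2 (beyond the scatter) and a number 51.8 percentage points lower from compound 2 to compound 3 (beyond the scatter), concern chain groups only and do not involve a ring, so they say less about compound 4.

Compound 4 is estimated to show an increase of a number 21.8 percentage points higher from compound 3 to compound 4 (beyond the scatter) and to come in near 40%, within a range from 15% to 65%.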

Compound 4, a percentage reported as inhibition, at one concentration (the size of the read-out at that concentration, not a potency): 71.6%
For compound 4 the middle estimate is 31.6 percentage points below the measured one; the measured number lies above the stated range.
By their numbers in this assay, from the lowest: compound 3; then compound 1; then compounds 2 and 4 (each within the scatter of the next).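

In this assay, a ring on the saturated chain carbon bound to an aromatic nitrogen can do far more than compound 1 suggested: 3-chlorophenyl in place of propyl gives a number 53.4 percentage points higher from compound 3 to compound 4 (beyond the scatter) in this series. The ring's substitution also matters, as 3-chlorophenyl in place of 2-fluorophenyl gives a number 30.9 percentage points higher from compound 1 to compound 4 (beyond the scatter) at this same position. Yet a ring is not needed for a high number, since 3-chlorophenyl in place of isobutyl gives only a number 1.6 percentage points higher from compound 2 to compound 4 (within the scatter) here.

No measurement at hand explains these differences. Going by these compounds, compounds carrying 3-fluorophenyl or 2-chlorophenyl would separate the effect of the halogen from that of its place on the ring, and how a chain ending in an amine or a carboxylic acid would fare stays open.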